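A few compounds are considered here, and "the series" means these few. Any claim that something is new, unique, unknown or untested is made for them only; others in the source may bear on it.

In a functional assay on COLO 205 cells (Homo sapiens) for inhibition, read by sulforhodamine B assay, with a stated time of 48 h, tested at 50 uM (a higher number here means more inhibition of growth at the concentration tested, a lower number less inhibition of growth), compound 2 (`COc1cc(/C=C/C(=O)/C=C/c2cccs2)ccc1OCc1cn(CCOc2cc(=O)oc3ccccc23)nn1`) gives 66% and so stands second of the three measured compounds. Compound 1 (`COc1cc(/C=C/C(=O)/C=C/c2cccc3ccccc23)ccc1OCc1cn(CCOc2cc(=O)oc3ccccc23)nn1`) gives 85% as the highest number and compound 3 (`COc1cc(/C=C/C(=O)/C=C/c2ccccc2)ccc1OCc1cn(CCCCOc2cc(=O)oc3ccccc23)nn1`) gives 31% as the lowest, both beyond the usual scatter from compound 2.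

Compound 4 (`COc1cccc(/C=C/C(=O)/C=C/c2ccc(OCc3cn(CCOc4cc(=O)oc5ccccc45)nn3)c(OC)c2)c1`) has not yet been measured. It differs from compound 2 in one group on a double-bonded chain carbon bound to a double-bonded chain carbon, with 3-methoxyphenyl in place of thiophen-2-yl (3-methoxyphenyl in place of thiophen-2-yl on a double-bonded chain carbon bound to a double-bonded chain carbon).

Among the measured compounds shown here, only one measured step touches this same place. It is a number 19 percentage points lower from compound 1 to compound 2 (beyond the scatter) when thiophen-2-yl replaces naphthalen-1-yl, so an exchange here has already moved the number by a modest amount. Compound 3 differs from compound 2 in more than one place, so its number does not isolate this exchange. For the measured compounds named here, no measured compound carries 3-methoxyphenyl, which leaves the direction uncertain.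

The expected change is therefore small, and this estimate puts it at a number 4 percentage points higher from compound 2 to compound 4 (within the scatter) without ruling out a modest move either way. For compound 4 the estimated value is 70% with an expected range from 48% to 88% in this measurement.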

Compound 4, percent growth inhibition at one concentration: 69%
Estimate against measurement, compound 4: 1 percentage points above; the range from low to high includes it.
By their numbers in this assay, from the lowest: compound 3; then compounds 2 and 4 (each within the scatter of the next); then compound 1.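

In this assay the exchange of thiophen-2-yl for 3-methoxyphenyl, on a double-bonded chain carbon bound to a double-bonded chain carbon, gives a number 3 percentage points higher from compound 2 to compound 4 (within the scatter) and so leaves the two groups indistinguishable, even though a five-membered aromatic ring with sulfur gives way to a six-membered ring of carbon only that has more heavy atoms. This place therefore does not respond to every exchange, and naphthalen-1-yl now stands apart from two different groups, since the other new step reads a number 16 percentage points lower from compound 1 to compound 4 (beyond the scatter) and joins a number 19 percentage points lower from compound 1 to compound 2 (beyond the scatter) as a move beyond the scatter. No measurement given here explains why naphthalen-1-yl differs from these two groups.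

As far as these compounds go, whether a group of another kind at this place, such as a 3-aminophenyl or a 3-carboxyphenyl, would keep the number in the same range or shift it remains open. Compound 3 differs from compound 4 in more than one place, so the effect of the longer chain, and of plain phenyl at this place, cannot be separated from these compounds.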